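The source may hold more compounds than are shown below. What is called first, only, known or untested is meant among the compounds shown, and "the series" means these compounds.

Compound 1 `Cc1cccc(C)c1-c1cccc(COc2ccc(CCC(=O)O)cn2)c1` gives 38 nM in a functional assay on CHO cells for agonist activity at Free fatty acid receptor 1 (Rattus norvegicus), read by calcium flux; a higher number here means that more compound is needed for the effect, a lower number that less compound is needed.
Compound 2 `Cc1cccc(C)c1-c1cccc(COc2ccc(CC(C)C(=O)O)cn2)c1` gives 2100 nM in this assay.
Compound 3 `COC(Cc1ccc(OCc2cccc(-c3c(C)cccc3C)c2)nc1)C(=O)O` gives only > 10000 nM in this assay, which is a limit of the assay and not a number.

Compound 3 therefore stands at the limit of > 10000 nM in this assay, at which 1 of the 3 values shown sits, the weakest of the three; the steps of an at least 260-fold higher number from compound 1 to compound 3 (2.42 log units; beyond the scatter) and an at least 4.7-fold higher number from compound 2 to compound 3 (0.67 log units; beyond the scatter) are both beyond the scatter. Compound 4 `Cc1cccc(C)c1-c1cccc(COc2ccc(C(F)CC(=O)O)cn2)c1` differs from compound 3 by 2-carboxy-1-fluoroethyl in place of 2-carboxy-2-methoxyethyl on an aromatic carbon. Going by the values given here, two measured steps touch this change. The step of a 55-fold higher number from compound 1 to compound 2 (1.74 log units; beyond the scatter) and the step of an at least 260-fold higher number from compound 1 to compound 3 (2.42 log units; beyond the scatter) show that putting a methyl or a methoxy on the saturated chain carbon bound to a carbonyl carbon and a saturated chain carbon costs a great deal of potency. Compound 4 removes that methoxy, which by itself points back toward compound 1. Among the compounds with values here, the name 2-carboxy-1-fluoroethyl, however, places the fluorine on another chain carbon, and no measured compound carries a substituent there, so the fluorine's own effect is unknown. On balance a large step down in the number is expected, an at least 66-fold lower number from compound 3 to compound 4 (1.82 log units; beyond the scatter), landing between compound 1 and compound 2. Compound 4 is estimated at 150 nM, with a range from 30 nM to 1500 nM.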

Compound 4, half-maximal effective concentration: 96 nM
The estimate for compound 4 lay 1.6-fold (0.19 log units) above the measured number, within the range that was stated.
By their numbers in this assay, from the lowest: compound 1; then compound 4; then compound 2. At a limit, above all of these: compound 3.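

Compound 3 has only a limit in this assay, which is not a true number: the limit of > 10000 nM in this assay, at which 1 of the 4 values shown sits.

Even so, an at least 100-fold lower number from compound 3 to compound 4 (2.01 log units; beyond the scatter) and a 22-fold lower number from compound 2 to compound 4 (1.34 log units; beyond the scatter) show that the side chain on this aromatic carbon, two atoms from the ring nitrogen, does not lose nearly all its potency whenever it gains a substituent, since 2-carboxy-1-fluoroethyl performs far better than 2-carboxy-2-methoxyethyl or 2-carboxypropyl. Fluoro in place of hydrogen on the chain carbon bound to the aromatic carbon costs only a modest amount, a 2.5-fold higher number from compound 1 to compound 4 (0.40 log units; beyond the scatter), though this is still beyond the scatter, whereas methyl on the chain carbon bound to the carbonyl carbon gives a large step, a 55-fold higher number from compound 1 to compound 2 (1.74 log units; beyond the scatter); this contrast rests on these few compounds and also involves two different groups.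

From the compounds shown here alone, it remains open whether a hydroxy group or a second fluorine on the chain carbon bound to the aromatic carbon would stay as close to compound 1 as the single fluoro does. Going by these compounds, it is also open whether a fluoro on the chain carbon bound to the carbonyl carbon would be as costly as methyl or methoxy there.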